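Swapping an Aryl Group for Ethyl on the Ring Nitrogen

A few compounds are considered here, and "the series" means these few. Any claim that something is new, unique, unknown or untested is made for them only; others in the source may bear on it.

Measured compounds:
- compound 1 `COc1ccccc1N1C(=O)CSC1c1cc(F)cc(C(=O)O)c1`: 0%
- compound 2 `COc1ccc(C)cc1N1C(=O)CSC1c1cccc(C(=O)NCCCCc2ccccc2)c1`: 79%
- compound 3 `O=C(NCCCCc1ccccc1)c1cccc(C2OCC(=O)N2c2cccc(F)c2)c1`: 32%

In a functional assay on SJSA-1 cells (Homo sapiens) for inhibition, read by CCK-8 assay, with a stated time of 72 h, tested at 1 uM (on this read-out lower numbers stand for less inhibition and higher numbers for more inhibition at the one concentration tested (going by the name of the read-out)), compound 2 gives 79%, the highest of the three numbers. Compound 3 sits well below it, and compound 1 gives the lowest number of all, both gaps lying beyond the scatter. Both compound 1 and compound 3 differ from compound 2 in more than one place, so no single change explains these gaps.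

Compound 4 `CCN1C(=O)CSC1c1cccc(C(=O)NCCCCc2ccccc2)c1` has not yet been tested. It keeps the amide chain of compound 2 but changes the group on the ring nitrogen: ethyl in place of 2-methoxy-5-methylphenyl on an amide-type nitrogen in a ring. Compound 3, which carries a different aryl group at that nitrogen together with an oxygen in place of the ring sulfur, already falls far below compound 2, which suggests that this part of the molecule matters for the read-out.

Compound 4 is therefore expected to lose inhibition, with an estimated step of a number 54 percentage points lower from compound 2 to compound 4 (beyond the scatter) beyond the scatter. Compound 4 is estimated to give 25% in this assay, in a range from 5% to 55%.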

Compound 4, a percentage reported as inhibition, at one concentration (the size of the read-out at that concentration, not a potency): 3%
Compound 4: the middle estimate sits 22 percentage points above what was measured, outside the stated range (below it).
By their numbers in this assay, from the lowest: compounds 1 and 4 (each within the scatter of the next); then compound 3; then compound 2.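

Within the data shown here, the pair compound 2 and compound 4 differs in one place only, so it gives the first clean reading of the group on the ring nitrogen: in this assay, ethyl in place of 2-methoxy-5-methylphenyl gives a number 76 percentage points lower from compound 2 to compound 4 (beyond the scatter). The amide chain is the same in both compounds, so that chain alone does not secure inhibition at this concentration, as compound 4 keeps it and gives 3%. No supporting measurement bears on why this swap has so large an effect.

Still open, as far as these compounds go, is whether the aromatic ring itself accounts for the step, or the methoxy and methyl groups on it. A plain phenyl on this nitrogen would help separate these, and a cyclohexyl would show whether a large ring without aromatic character can take the place of the aryl group.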